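Hydroxyphenyl sulfonamide after an inactive series

A few compounds are considered here, and "the series" means these few. Any claim that something is new, unique, unknown or untested is made for them only; others in the source may bear on it.

Compound 3 `CCc1ccc(S(=O)(=O)Nc2ccc(-c3nc4ccccc4o3)cc2)cc1` is known in an assay on isolated protein for inhibition of malate dehydrogenase, mitochondrial (Sus scrofa), with stated times of 45 min and 30 min (on this read-out lower numbers stand for stronger inhibition and higher numbers for weaker inhibition), only as a limit: compound 3 gives > 63000 nM. Compound 1 `Cc1ccccc1S(=O)(=O)Nc1ccc(-c2nc3ccccc3o2)cc1` gives > 63000 nM, likewise a limit. Compound 2 `O=S(=O)(Nc1ccc(-c2nc3ccccc3o2)cc1)c1ccc(Cl)s1` gives > 63000 nM, also a limit. The three values thus sit together at the limit of > 63000 nM in this assay, at which 3 of the 3 values shown sit, and the steps among them, a step that the two limits leave unreadable from compound 1 to compound 2, a step that the two limits leave unreadable from compound 1 to compound 3 and a step that the two limits leave unreadable from compound 2 to compound 3, cannot be read in size or direction. Compound 4 `O=S(=O)(Nc1ccc(-c2nc3ccccc3o2)cc1)c1cccc(O)c1` differs from compound 3 by 3-hydroxyphenyl in place of 4-ethylphenyl on a sulfonyl sulfur. Among the measured compounds shown here, no measured step bears on this change, and none is readable, so no direction can be drawn from them. Compound 4 is therefore expected to stay close to the limit, the estimated step being a step that the limit leaves unreadable from compound 3 to compound 4. The estimate for compound 4 is 100000 nM, within 30000 nM to 400000 nM.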

Compound 4, half-maximal inhibitory concentration: > 63000 nM
Compound 4 ended at the assay's limit (the forecaster's own chance of this, stated with the estimate: 75%); the middle value is on the limit's open side.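

Among the compounds shown here, compound 4 sits with compound 1, compound 2 and compound 3 at one limit, so no step from any of them to compound 4 can be read in this assay: the limit of > 63000 nM in this assay, at which 4 of the 4 values shown sit. The compounds shown leave open which group on the sulfonyl sulfur, if any, would bring a value inside that limit.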